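Replacing the anilino arm on the carbonyl: series notes

The compounds below may be only part of what the source reports. "The series", "measured", "known", "first", "only" and "open" are said of these compounds alone.

Measured so far:
compound 1 `O=C(Nc1cccc(-n2cc(-c3ccncc3)c(-c3cc(O)cc(Cl)c3)n2)c1)Nc1ccc(Cl)c(C(F)(F)F)c1`, in a functional assay on OVCAR-8 cells (Homo sapiens) for inhibition, read by sulforhodamine B assay, with a stated time of 48 h, tested at 0.01 uM (a higher number here means a weaker effect of the compound at the concentration tested, a lower number a stronger effect), compound 1 gives 102%
compound 2 `COc1cc(Cl)cc(-c2nn(-c3cccc(NC(=O)Nc4ccc(Cl)c(C(F)(F)F)c4)c3)cc2-c2ccncc2)c1`, in this assay compound 2 gives 98%

Compound 2 holds the lowest of the two numbers in this assay, with compound 1 nearest at a number 4 percentage points lower from compound 1 to compound 2 (within the scatter), so the two are not separated and both sit at essentially full activity at the concentration tested.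

Compound 3 `COc1cc(Cl)cc(-c2nn(-c3cccc(NC(=O)c4cccc(C(F)(F)F)c4)c3)cc2-c2ccncc2)c1` is the next member; it differs from compound 2 as follows: 3-(trifluoromethyl)phenyl in place of (4-chloro-3-(trifluoromethyl)phenyl)amino on a carbonyl carbon. Going by the values given here, the only measured step, a number 4 percentage points lower from compound 1 to compound 2 (within the scatter), concerns a methyl on an oxygen and does not touch the carbonyl carbon, so no measured step bears directly on this change. Given that both measured compounds read near full activity, compound 3 is expected to behave alike, and the step of a number 1 percentage points lower from compound 2 to compound 3 (within the scatter) is expected to be none beyond the scatter. Compound 3 is estimated at 97%, with a range from 85% to 108%.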

Compound 3, a percentage reported as activity, at one concentration (the size of the read-out at that concentration, not a potency): 103%
The estimate for compound 3 lay 6 percentage points below the measured number; measured number inside the range.
By their numbers in this assay, from the lowest: compounds 2, 1 and 3 (each within the scatter of the next).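

In this assay, going by these compounds alone, the first measured change on the carbonyl carbon gives a number 5 percentage points higher from compound 2 to compound 3 (within the scatter). This exchange removes the amino nitrogen with its hydrogen-bond donor and the chlorine of the leaving arm, yet compound 2 and compound 3 are not separated, so at this concentration neither feature can be shown to matter. No measurement available here bears on why the two arms read alike.

On these data alone, it remains open whether any group on this carbonyl carbon can give a number apart from these three, for example a simple alkyl chain or a morpholine in place of the aromatic arm. A carboxylic acid or an amine on the phenyl ring of the arm is equally untested in what is shown here.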